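A Fluoro Substituent Tested Across Two Related Cores

A few compounds are considered here, and "the series" means these few. Any claim that something is new, unique, unknown or untested is made for them only; others in the source may bear on it.

Compound 1, `COc1ccc(-c2ccc(C(=O)Nc3ccc(Oc4ccnc5[nH]ccc45)cc3)nc2)cc1`, in a functional assay on A549 cells (Homo sapiens) for cytotoxicity, read by MTT assay, with a stated time of 72 h (on this read-out lower numbers stand for stronger inhibition and higher numbers for weaker inhibition), gives > 10000 nM, which is a limit of the assay and not a number.
Compound 2, `O=C(Nc1ccc(Oc2ccnc3[nH]ccc23)cc1)c1cc(-c2ccccc2)ccn1`, in this assay gives 2920 nM.
Compound 3, `COc1ccc(-c2ccc(C(=O)Nc3ccc(Oc4ccnc5[nH]ccc45)c(F)c3)nc2)cc1`, in this assay gives 2240 nM.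

Compound 3 is compound 1 with fluoro in place of hydrogen on an aromatic carbon. As far as these compounds go, that change produced an at least 4.4-fold lower number from compound 1 to compound 3 (0.64 log units; beyond the scatter), though compound 1 sits at the limit of > 10000 nM in this assay, at which 1 of the 3 values shown sits, so the full size of the step remains open. Compound 2 and compound 1 are built on different cores, and the difference between the two cores is not broken down here. Compound 4, `O=C(Nc1ccc(Oc2ccnc3[nH]ccc23)c(F)c1)c1cc(-c2ccccc2)ccn1`, is compound 2 with fluoro in place of hydrogen on an aromatic carbon, the same change in the same surroundings as from compound 1 to compound 3. The values of compound 2 and compound 3 lie within the scatter of each other. For compound 4 a step of about a 1.9-fold lower number from compound 2 to compound 4 (0.29 log units; within the scatter) is expected, resting on the step seen after the same change, an at least 4.4-fold lower number from compound 1 to compound 3 (0.64 log units; beyond the scatter), while allowing that this earlier step only shows a limit. The estimate for compound 4 is 1500 nM, expected to fall between 500 nM and 4500 nM.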

Compound 4, half-maximal inhibitory concentration: 4950 nM
Compound 4: the middle estimate sits 3.3-fold (0.52 log units) below what was measured, and the stated range ends below it.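

In this assay, the step seen for fluoro in place of hydrogen on an aromatic carbon did not carry over from one core to the other, and the two steps differ by more than the scatter: the same change on two cores in this assay, an at least 4.4-fold lower number (0.64 log units; beyond the scatter) from compound 1 to compound 3 and a 1.7-fold higher number (0.23 log units; within the scatter) from compound 2 to compound 4, at least 7.5-fold (0.87 log units) apart, beyond the scatter of two such steps. The second core gives a 1.7-fold higher number from compound 2 to compound 4 (0.23 log units; within the scatter), so there the two values cannot be told apart, and the gain seen on the first core does not appear. This single pair on each core gives no general rule and does not show why the cores differ, and the full size of the first step stays open, since that step starts from a limit: the limit of > 10000 nM in this assay, at which 1 of the 4 values shown sits.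

The compounds shown leave open whether chloro or an amine on that same aromatic carbon would behave alike on the two cores. They also leave open how the fluoro change would fare on a third core.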